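A few compounds are considered here, and "the series" means these few. Any claim that something is new, unique, unknown or untested is made for them only; others in the source may bear on it.

Measured compounds and their values:

Compound 1, `COC(=O)N1CCCc2cc(S(=O)(=O)N3CC(c4ccccc4)NC3=O)ccc21`: 4020 nM
Compound 2, `CCOC(=O)N1CCCc2cc(S(=O)(=O)N3CC(c4ccccc4)NC3=O)ccc21`: 2780 nM
Compound 3, `O=C(CCl)N1CCCc2cc(S(=O)(=O)N3CC(c4ccccc4)NC3=O)ccc21`: 11200 nM

All three share one core and differ only in the group on the carbonyl carbon attached to the ring nitrogen. In a functional assay on COLO 205 cells (Homo sapiens) for antiproliferative activity, read by MTT assay (a higher number here means a weaker inhibitor, a lower number a stronger inhibitor), compound 2 gives the lowest of the three numbers, but the step is a 1.4-fold lower number from compound 1 to compound 2 (0.16 log units; within the scatter), so these two cannot be told apart. Compound 3 sits apart: the change is a 2.8-fold higher number from compound 1 to compound 3 (0.44 log units; beyond the scatter) and a 4.0-fold higher number from compound 2 to compound 3 (0.61 log units; beyond the scatter), a modest weakening when chloromethyl replaces the alkoxy group.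

Compound 4, `O=C(NC1CCCCC1)N1CCCc2cc(S(=O)(=O)N3CC(c4ccccc4)NC3=O)ccc21`, is the next step from compound 2. The change is cyclohexylamino in place of ethoxy on a carbonyl carbon. The measured steps give only indirect guidance: swapping methoxy for ethoxy did nothing beyond the scatter, while replacing the alkoxy group with chloromethyl cost a modest amount. Compound 4 keeps a heteroatom on the carbonyl carbon, as the carbamates do, but brings a hydrogen-bond donor and a ring, neither of which has a precedent here. The expectation is therefore a step of a 1.1-fold higher number from compound 2 to compound 4 (0.03 log units; within the scatter), essentially none beyond the scatter, with wide uncertainty. Compound 4 is estimated at 3000 nM, within a range of 1000 nM to 10000 nM.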

Compound 4, half-maximal inhibitory concentration: 3890 nM
For compound 4 the middle estimate is 1.3-fold (0.11 log units) below the measured one; the measured number falls inside the stated range.
By their numbers in this assay, from the lowest: compounds 2, 4 and 1 (each within the scatter of the next); then compound 3.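

In this assay, the position on the carbonyl carbon accepts a much larger group carrying a ring and a hydrogen-bond donor without a readable change: cyclohexylamino in place of ethoxy gives a 1.4-fold higher number from compound 2 to compound 4 (0.15 log units; within the scatter) and cyclohexylamino in place of methoxy gives a 1.0-fold lower number from compound 1 to compound 4 (0.01 log units; within the scatter). Moving away from the alkoxy groups therefore does not by itself cost activity, and the earlier loss is not shared by every replacement, as cyclohexylamino in place of chloromethyl gives a 2.9-fold lower number from compound 3 to compound 4 (0.46 log units; beyond the scatter) and so places the new compound with the two carbamates rather than with the chloromethyl compound. No measurement shown here accounts for this tolerance at the position.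

The compounds shown leave open whether the higher number of compound 3 belongs to the chlorine or to any carbon-linked group on the carbonyl, a question that a plain methyl at the same place would address. They also leave open how the cyclohexyl ring and the nitrogen hydrogen each contribute, which dimethylamino or phenylamino groups would begin to separate.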